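Shortening the acyl chain beside a limit value

A few compounds are considered here, and "the series" means these few. Any claim that something is new, unique, unknown or untested is made for them only; others in the source may bear on it.

Working notes on a small set of amides built on one shared core. Compound 1 `O=C(Nc1ccccc1O)C1CCc2ccccc2N1C(=O)c1ccccc1Cl`, compound 2 `CCCC(=O)N1c2ccccc2CCC1C(=O)Nc1cc(C(F)(F)F)cc(C(F)(F)F)c1` and compound 3 `CCCC(=O)N1c2ccccc2CCC1C(=O)Nc1ccccc1C(F)(F)F` differ from one another in their acyl and anilide parts. In a functional assay on HCT-15 cells (Homo sapiens) for cytotoxicity, read by sulforhodamine B assay, with a stated time of 72 h (a higher number here means a weaker inhibitor of growth, a lower number a stronger inhibitor of growth), compound 1 gives 44900 nM. In this assay compound 2 gives 21900 nM. For compound 3 this assay reports only a limit, > 70000 nM, so no number is known for it. Compound 3 thus sits at the limit of > 70000 nM in this assay, at which 1 of the 3 values shown sits, the upper edge of what the assay reports.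

Compound 4 `CCC(=O)N1c2ccccc2CCC1C(=O)Nc1ccccc1C(F)(F)F` differs from compound 3 in one place: hydrogen in place of methyl on a saturated chain carbon, two bonds along the chain from a carbonyl carbon, which reads as propylcarbonyl to propanoyl. Going by the values given here, no pair of measured compounds shows what such a shortening does in this assay. The step that the limit leaves unreadable from compound 3 to compound 4 is expected to be none beyond the scatter. Compound 4 is therefore estimated at about 85000 nM, most likely again reported as a limit, with a range from 30000 nM to 250000 nM.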

Compound 4, concentration for 50% growth inhibition: > 80000 nM
Compound 4: no number, only a limit (the forecaster's own chance of this, stated with the estimate: 70%); the middle value is on the limit's open side.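

In this assay compound 3 is reported only as a limit, > 70000 nM. Compound 4 is likewise only a limit, > 80000 nM, so no step can be read between these two compounds. From the compounds shown here alone, what shortening propylcarbonyl to propanoyl does to growth inhibition remains open.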